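The compounds below may be only part of what the source reports. "The series", "measured", "known", "first", "only" and "open" are said of these compounds alone.

Compound 2 `Nc1nc(NCc2ccccc2)nc(-c2cc(Cl)ccc2CO)n1` gives 4.49 in a functional assay on cells for positive allosteric modulation of G-protein coupled receptor 68 (Homo sapiens), read by a luciferase reporter and cAMP accumulation, with a stated time of 30 min, at pH 6.8 and pH 8.3, in the presence of a further agent that is not named here (on this read-out lower numbers stand for lower potency and higher numbers for higher potency (the scale is a negative logarithm)), and compound 1 `Nc1nc(NCc2ccccc2)nc(-c2cc(F)ccc2CO)n1` gives 4.58 in this assay, the two numbers sitting within the usual scatter of each other. Compound 3 `COc1ccc(CO)c(-c2nc(N)nc(NCc3ccccc3)n2)c1` differs from compound 2 by methoxy in place of chloro on an aromatic carbon. For the measured compounds named here, the only measured step at this position, a number 0.09 log units lower from compound 1 to compound 2 (within the scatter), bears on the change and was small. An exchange of one substituent for another here is therefore expected to move this assay little, and compound 3 is estimated to show a step of a number 0.01 log units higher from compound 2 to compound 3 (within the scatter). Compound 3 is thus expected to give about 4.5, within a range from 4 to 5.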

Compound 3, negative logarithm of the antagonist equilibrium constant: 3.99
Beside the measured number, compound 3's estimate is 0.51 log units above it; the measured number lies below the stated range.
By their numbers in this assay, from the lowest: compound 3; then compounds 2 and 1 (each within the scatter of the next).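

The position para to a hydroxymethyl group is not indifferent to its substituent in this assay as the halogen exchange alone had suggested: methoxy gives a number 0.50 log units lower from compound 2 to compound 3 (beyond the scatter) and a number 0.59 log units lower from compound 1 to compound 3 (beyond the scatter) in the same series. The small step between the two halogens therefore did not carry over to methoxy. No measured evidence accounts for this drop.

The compounds shown leave open whether the drop is particular to methoxy or extends to a hydroxyl, a methyl or an amine here. They also leave open how a longer ether chain, such as ethoxy, would read.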